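Swapping methyl for nitro on the aromatic ring

A few compounds are considered here, and "the series" means these few. Any claim that something is new, unique, unknown or untested is made for them only; others in the source may bear on it.

Measured in a functional assay on PC-3 cells (Homo sapiens) for cytotoxicity, read by MTT assay, with a stated time of 72 h; a lower number here means a stronger inhibitor, a higher number a weaker inhibitor
Compound 1 `CC1=C(/C=C/C(=O)/C=C/c2cccc([N+](=O)[O-])c2)C(C)(C)CCC1` gives 10000 nM
Compound 2 `CC1=C(/C=C/C(=O)/C=C/c2cccc(F)c2)C(C)(C)CCC1O` gives 16000 nM
Compound 3 `CC1=C(/C=C/C(=O)/C=C/c2cccc(C)c2)C(C)(C)CCC1O` gives 6200 nM

Compound 3 stands clearly apart from compound 2 but within the usual scatter of compound 1. Compound 4 `CC1=C(/C=C/C(=O)/C=C/c2cccc([N+](=O)[O-])c2)C(C)(C)CCC1O` has nitro in place of methyl on an aromatic carbon, meta to a large group, a change counted as nitro in place of methyl on an aromatic carbon. For the measured compounds named here, the one measured step at this carbon is the modest 2.6-fold lower number from compound 2 to compound 3 (0.41 log units; beyond the scatter), with methyl in place of fluoro. Compound 1 also carries nitro and gives 10000 nM, so no step beyond the scatter is expected in this assay, though a slightly higher number is possible. The expected change is a 1.6-fold higher number from compound 3 to compound 4 (0.21 log units; within the scatter). Compound 4 is estimated at 10000 nM, with an expected range from 4000 nM to 25000 nM.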

Compound 4, half-maximal inhibitory concentration: 5800 nM
For compound 4 the middle estimate is 1.7-fold (0.24 log units) above the measured one, within the range that was stated.
By their numbers in this assay, from the lowest: compounds 4, 3, 1 and 2 (each within the scatter of the next, the first and the last beyond it).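

In this assay, nitro and methyl on this aromatic carbon cannot be told apart, with a 1.1-fold lower number from compound 3 to compound 4 (0.03 log units; within the scatter). Nitro in place of fluoro gives a 2.8-fold lower number from compound 2 to compound 4 (0.44 log units; beyond the scatter), so among the three groups compared here, only fluoro stands apart from the others. With nitro on the aromatic ring, adding hydroxy on the saturated ring carbon gives a 1.7-fold lower number from compound 1 to compound 4 (0.24 log units; within the scatter), a change within the scatter.

Nothing measured here explains these results. From the compounds shown here alone, whether an amine or a carboxylic acid on this aromatic carbon would shift the number remains open.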